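The source may report more compounds than this note shows. Statements on the series, on what has been measured and on what is new or still open speak of the compounds shown alone.

Measured compounds
- compound 1 `O=C(Nc1ccccc1O)c1cccc(N2C(=O)c3ccccc3C2=O)c1`; in an in vitro functional assay on HEK293-A cells for antagonist activity at metabotropic glutamate receptor 5 (Rattus norvegicus), read by calcium flux (a lower number here means a stronger inhibitor, a higher number a weaker inhibitor), compound 1 gives 77 nM.
- compound 2 `O=C(Nc1ccc(Cl)c(-c2nc3ccccc3[nH]2)c1)c1ccc(Br)o1`; in this assay compound 2 gives 85 nM.
- compound 3 `COc1ccccc1C(=O)Nc1cccc(NC(=O)c2ccc(F)cc2)c1`; in this assay compound 3 gives > 30000 nM, which is a limit of the assay and not a number.

Compound 3 therefore stands at the limit of > 30000 nM in this assay, at which 1 of the 3 values shown sits, with no measured inhibition to compare against. Compound 1 and compound 2 both return numbers, and the two values lie within the usual scatter of each other, so no order between them is claimed. Going by the values given here, compound 3 differs from both in its whole skeleton, and no single-change step connects any two of the measured compounds.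

Compound 4 `COCC(=O)Nc1cccc(NC(=O)c2ccccc2OC)c1` is derived from compound 3 by methoxymethyl in place of 4-fluorophenyl on a carbonyl carbon. The only fixed point is that compound 3 is at the limit; nothing measured here shows whether a change at this carbonyl moves the value. The working expectation is that the step of a number no higher from compound 3 to compound 4 (the limit leaves the size open) is about none beyond the scatter, with the value most likely staying at a limit. Compound 4 is accordingly estimated at 30000 nM, with a range from 8000 nM to 100000 nM.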

Compound 4, half-maximal inhibitory concentration: > 30000 nM
Compound 4 ended at the assay's limit; the forecaster's own chance of this, stated with the estimate: 75%; the middle value lies on the limit itself.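

Compound 3 and compound 4 both sit at a limit of this assay, not at a number, so no step between them can be read: the limit of > 30000 nM in this assay, at which 2 of the 4 values shown sit.

The compounds shown leave open whether any group on this carbonyl carbon can give a measurable value in this series.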